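Amide variation in a two-compound stilbene series

The source may report more compounds than this note shows. Statements on the series, on what has been measured and on what is new or still open speak of the compounds shown alone.

Measured so far:
Compound 1, `COc1ccc(/C=C/c2cc(OC)cc(OC)c2/C=C/C(=O)Nc2cc(OC)c(OC)c(OC)c2)cc1`, gives 8150 nM in a functional assay on B16-F10 cells (Mus musculus) for inhibition, read by MTT assay, with a stated time of 48 h; a higher number here means a weaker inhibitor, a lower number a stronger inhibitor.
Compound 2, `COc1ccc(/C=C/c2cc(OC)cc(OC)c2/C=C/C(=O)N2CCCC2)cc1`, gives 9280 nM in this assay.

The two values sit close together: compound 1 and compound 2 lie within the usual scatter of each other, so neither can be called the stronger inhibitor on these numbers. The shared core is the same in both; only the amide substituent differs, and that difference is not a single-point step and carries no counted change.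

Compound 3, `COc1ccc(/C=C/c2cc(OC)cc(OC)c2/C=C/C(=O)N(CC(C)C)CC(C)C)cc1`, keeps the core of compound 2 and alters the amide: diisobutylamino in place of pyrrolidin-1-yl on a carbonyl carbon. Going by the values given here, no measured step covers a change of this kind, so there is nothing that points in either direction. The step from compound 2 to compound 3 is expected to be small, a 1.1-fold higher number from compound 2 to compound 3 (0.03 log units; within the scatter), with no change beyond the scatter anticipated. Compound 3 is therefore estimated at 10000 nM, with a range from 4000 nM to 25000 nM.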

Compound 3, half-maximal inhibitory concentration: 4850 nM
Compound 3: the middle estimate sits 2.1-fold (0.31 log units) above what was measured, and the stated range covers the measured number.
By their numbers in this assay, from the lowest: compounds 3, 1 and 2 (each within the scatter of the next).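

In this assay, going by these compounds alone, diisobutylamino in place of pyrrolidin-1-yl on a carbonyl carbon gives a 1.9-fold lower number from compound 2 to compound 3 (0.28 log units; within the scatter) and is the first step that differs in one place. The amide position therefore carries the loss of the ring and a rise in heavy atoms with no change beyond the scatter, which the unmatched pair of compound 1 and compound 2 could not show. No measurement bears on what sets the size of this step.

Still open, as far as these compounds go, is whether any amide group at this position moves the number beyond the scatter, for example morpholin-4-yl, with an oxygen in the ring, or diethylamino, with shorter chains. A carboxylic acid or an amine at the end of a longer chain on the amide nitrogen is equally untested by the compounds shown here.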